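Removing the amino group from compound 1

A few compounds are considered here, and "the series" means these few. Any claim that something is new, unique, unknown or untested is made for them only; others in the source may bear on it.

Compound 1 `Nc1nc(Cl)c2ncn(Cc3ccccc3CCl)c2n1` carries a chloromethylbenzyl group on the shared core. In a functional assay on UACC-62 cells (Homo sapiens) for cytotoxicity, read by sulforhodamine B assay, with a stated time of 48 h (a higher number here means a weaker inhibitor of growth, a lower number a stronger inhibitor of growth), compound 1 gives 4370 nM. Among the three measured compounds, compound 1 sits level with compound 3 `ClCc1ccc(Cn2cnc3c(Cl)nc(Cl)nc32)cc1`, which gives 4370 nM, and the two together hold the highest numbers. Compound 2 `ClCc1cccc(Cn2cnc3nc(Cl)nc(Cl)c32)c1` gives 2180 nM, a difference from compound 1 that stays within the scatter.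

Compound 4 `ClCc1ccccc1Cn1cnc2c(Cl)ncnc21` differs from compound 1 in one place: hydrogen in place of amino on an aromatic carbon. Among the measured compounds shown here, no measured pair shows what this change does on its own. Compound 4 is expected to stay close to compound 1, with a step from a 1.1-fold lower number from compound 1 to compound 4 (0.04 log units; within the scatter) of no size beyond the scatter. Compound 4 is therefore estimated at 4000 nM, within a range from 1500 nM to 12000 nM.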

Compound 4, concentration for total growth inhibition: 6600 nM
Beside the measured number, compound 4's estimate is 1.7-fold (0.22 log units) below it; measured number inside the range.
By their numbers in this assay, from the lowest: compounds 2, 1, 3 and 4 (each within the scatter of the next, the first and the last beyond it).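

The change of amino to hydrogen, on the aromatic carbon between two ring nitrogen atoms, now has a measured size: in this assay it is a 1.5-fold higher number from compound 1 to compound 4 (0.18 log units; within the scatter) and no more. In this one pair, compound 4 keeps growth inhibition in the same range as compound 1 without the amino group. Nothing available explains this result.

As far as these compounds go, whether a methyl or methoxy group on this carbon would move the number beyond the scatter stays open. So does whether this step would hold with a different benzyl group on the shared core.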